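A few compounds are considered here, and "the series" means these few. Any claim that something is new, unique, unknown or untested is made for them only; others in the source may bear on it.

Compound 1 `O=C(CSC(=S)N[C@H]1CCOC1=O)Nc1ccccc1`: in a functional assay on EC9706 cells (Homo sapiens) for cytotoxicity, read by MTT assay, with a stated time of 72 h (a higher number here means a weaker inhibitor, a lower number a stronger inhibitor), compound 1 gives > 128000 nM, which is a limit of the assay and not a number.
Compound 2 `COc1ccc(NC(=O)CSC(=S)N[C@H]2CCOC2=O)cc1`: compound 2 gives > 128000 nM, again a limit rather than a number.
Compound 3 `O=C(CCl)Nc1ccc(C(=O)/C=C/c2ccc(Cl)cc2)cc1`: compound 3 gives 8340 nM.

Among the measured compounds shown here, compound 3 is thus the only member of the set with a real number; the other two values stop at the limit of > 128000 nM in this assay, at which 2 of the 3 values shown sit. Compound 4 `O=C(CCl)Nc1ccc(C(=O)/C=C/c2ccccc2)cc1` has not yet been measured. It differs from compound 3 in one place: hydrogen in place of chloro on an aromatic carbon. For the measured compounds named here, the only measured step in the set, a step that the two limits leave unreadable from compound 1 to compound 2, is unreadable, and it also sits on a different core from the one shared by compound 3 and compound 4, so it offers no guidance on taking away a chloro. Going by the values given here, no measured step bears on the change from compound 3 to compound 4, and the expectation therefore rests on the value of compound 3 alone. The step of a 1.4-fold higher number from compound 3 to compound 4 (0.16 log units; within the scatter) is estimated to be small, a modest loss of potency that may well stay within the usual scatter. Compound 4 is accordingly expected to give about 12000 nM, with a range from 4000 nM to 36000 nM.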

Compound 4, half-maximal inhibitory concentration: 6370 nM
Estimate against measurement, compound 4: 1.9-fold (0.28 log units) above, and the stated range covers the measured number.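

In this assay, among the compounds shown here, replacing chloro with hydrogen on the aromatic carbon para to a large group, which turns 4-chlorophenyl into phenyl, gives a 1.3-fold lower number from compound 3 to compound 4 (0.12 log units; within the scatter), the first step in this set that can be read as a number. At this position, then, the two groups cannot be told apart in this measurement, and the chloro is not needed for a measurable value on this shared core: compound 4 gives 6370 nM. Nothing measured here offers an explanation for this small step, and no property of either group is available to account for it.

On these data alone, only chloro and hydrogen can be compared at this place, so it remains open whether a different group there, such as an amine, a carboxylic acid or a longer chain, would move the number beyond the usual scatter. As far as these compounds go, the rest of the shared core is identical in compound 3 and compound 4, and what those other parts contribute to the cytotoxic effect also stays open.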